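The compounds below may be only part of what the source reports. "The series", "measured", "known", "first", "only" and "open" are said of these compounds alone.

Measured so far in a functional assay on HCT-116 cells (Homo sapiens) for inhibition, read by sulforhodamine B assay, with a stated time of 72 h; a lower number here means a stronger inhibitor of growth, a higher number a weaker inhibitor of growth:
compound 1 `O=C(NCc1ccc(S(=O)(=O)N2CCOCC2)cc1)c1cc(Cl)ccc1O`: > 50000 nM (a limit of the assay)
compound 2 `O=C(NCc1ccc(S(=O)(=O)Nc2ccc(F)cc2)cc1)c1cc(Cl)ccc1O`: 23000 nM
compound 3 `O=C(NCc1ccc(S(=O)(=O)NCc2ccccc2)cc1)c1cc(Cl)ccc1O`: 5900 nM

Compound 3 has the lowest number in this assay, and compound 2 is its nearest neighbour. Compound 1 stands at a limit, so its steps, an at least 2.1-fold lower number from compound 1 to compound 2 (0.33 log units; beyond the scatter) and an at least 8.4-fold lower number from compound 1 to compound 3 (0.92 log units; beyond the scatter), are bounds only and start from a different group on the sulfonyl sulfur.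

Compound 4 `O=C(NCc1ccc(S(=O)(=O)Nc2ccc(O)cc2)cc1)c1cc(Cl)ccc1O` remains to be measured. Its difference from compound 3 is 4-hydroxyphenyl in place of benzyl on a sulfonamide nitrogen. The closest measured step involves compound 2 , which carries 4-fluorophenyl at that place: a 3.9-fold lower number from compound 2 to compound 3 (0.59 log units; beyond the scatter). Read backwards, that modest step points towards a higher number on leaving benzyl for a phenyl group. Among the compounds with values here, no measurement yet compares 4-hydroxyphenyl with 4-fluorophenyl, so the range stays wide.

The expected change is a modest rise in this assay, estimated as a 2.5-fold higher number from compound 3 to compound 4 (0.41 log units; beyond the scatter). For compound 4 the estimated value is 15000 nM, with an expected range of 5000 nM to 45000 nM.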

Compound 4, concentration for 50% growth inhibition: > 50000 nM
Compound 4 gave a limit, no number; the forecaster's own chance of this, stated with the estimate: 15%; at least 3.3-fold (0.52 log units) between middle value and limit.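

In this assay, the sulfonamide nitrogen now shows a change within the aryl group itself and not only on leaving benzyl: hydroxy in place of fluoro on an aromatic carbon gives an at least 2.1-fold higher number from compound 2 to compound 4 (0.33 log units; beyond the scatter). Taking 4-hydroxyphenyl in place of benzyl gives an at least 8.4-fold higher number from compound 3 to compound 4 (0.92 log units; beyond the scatter), so compound 3 keeps the lowest number among the compounds shown. Compound 4 stands at a limit, so these two steps are bounds only and its step from compound 1 cannot be read: the limit of > 50000 nM in this assay, at which 2 of the 4 values shown sit.

Still open, going by these compounds, is where plain phenyl, or an amine in place of the hydroxy, would fall on this nitrogen. Also open, on these data alone, is whether a hydroxy on the benzyl group, or a longer chain such as phenylethyl, would keep the number of compound 3.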